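This account rests on a few compounds, and the source may have more. Where it says the series, first, only, none or still open, it means among the compounds named here.

Compound 1 `C=CCn1c(SCC(=O)c2ccccc2)nnc1-c1ccccc1`: in a functional assay on the whole organism (strain albino) for inhibition, with Rattus norvegicus as the target, read by paw edema, with a stated time of 4 h, at a dose of 0.28 mmol/kg by the oral route (on this read-out lower numbers stand for less inhibition and higher numbers for more inhibition at the one dose given (going by the name of the read-out)), compound 1 gives 66%.
Compound 2 `CCn1c(SCC(=O)c2ccccc2)nnc1-c1ccc(OC)cc1`: in this assay compound 2 gives 70%.

Among the compounds with values here, of the two numbers so far, compound 2 has the higher one, but its nearest neighbour, compound 1, lies close to it, at a gap that is within the usual scatter of repeated measurements, so the two compounds cannot be told apart on this read-out. Within the data shown here, no pair of measured compounds differs in a single place, so no single step has yet been seen.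

The next compound, compound 3 `CCn1c(SCC(=O)c2ccccc2)nnc1-c1ccccc1`, is reached from compound 2 by one change: hydrogen in place of methoxy on an aromatic carbon. Cut one bond further out, the change reads 4-methoxyphenyl to phenyl, while the rest of the shared core is untouched.

Among the measured compounds shown here, with no measured step of this kind to lean on, and with compound 1 and compound 2 sitting within the scatter of each other, the expected step from compound 2 to compound 3 is a number 4 percentage points lower from compound 2 to compound 3 (within the scatter), that is, no change beyond the scatter. Compound 3 is therefore estimated at 66% in this assay, within a range of 50% to 80%.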

Compound 3, a percentage reported as inhibition, in the whole organism at one dose (the size of the read-out at that dose, not a potency): 63%
Compound 3: middle estimate off by 3 percentage points, on the high side; the range from low to high includes it.
By their numbers in this assay, from the lowest: compounds 3, 1 and 2 (each within the scatter of the next).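

In this assay, within the data shown here, the change from 4-methoxyphenyl to phenyl, with hydrogen in place of methoxy on an aromatic carbon, gives a number 7 percentage points lower from compound 2 to compound 3 (within the scatter) and is the first single change seen at this position, so on this read-out the methoxy group cannot be told apart from hydrogen there. Among these compounds, compound 3 also supplies the first step at the other place, methyl in place of vinyl on a saturated chain carbon bound to an aromatic nitrogen, which gives a number 3 percentage points lower from compound 1 to compound 3 (within the scatter) and so leaves these two compounds equally inseparable. Nothing available bears on why neither change separates its pair.

The compounds shown leave open whether an amine or a carboxylic acid on that aromatic carbon would shift the number beyond the scatter, and whether a longer chain in place of the ethyl or allyl group on the aromatic nitrogen would do so. With a single dose and a single time, they also leave open whether any of these compounds differ in potency.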